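The compounds below may be only part of what the source reports. "The series", "measured", "known", "first", "only" and "open" are said of these compounds alone.

In an assay on HEK293 cells for agonist activity at Toll-like receptor 8 (Homo sapiens), read by spectrophotometry (on this read-out lower numbers stand for an effect already at smaller amounts and higher numbers for an effect only at larger amounts of compound), compound 1 `CCCCNc1nc(N)nc(C)c1CCCCO` gives 1310 nM, the highest number among the three compounds measured. Compound 2 `CCCCNc1nc(N)nc(C)c1CCCN1C(=O)c2ccccc2C1=O` gives 453 nM and compound 3 `CCCCNc1nc(N)nc(C)c1CCCN(C)C` gives 126 nM. Compound 4 `CCCCNc1nc(N)nc(C)c1CCCc1ccccc1` differs from compound 1 as follows: phenyl in place of hydroxymethyl on a saturated chain carbon, three bonds along the chain from an aromatic carbon. For the measured compounds named here, only one measured step touches the same position: a 10-fold lower number from compound 1 to compound 3 (1.02 log units; beyond the scatter). That step replaced the hydroxymethyl group with dimethylamino, not phenyl, and compound 2 shows that a larger group at the same place also gives a lower number than compound 1. On this basis compound 4 is expected to give a lower number than compound 1 in this assay, by a step of a 3.3-fold lower number from compound 1 to compound 4 (0.52 log units; beyond the scatter), a moderate step rather than the large one seen for compound 3. The estimate for compound 4 is 400 nM, with a range from 130 nM to 1300 nM.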

Compound 4, half-maximal effective concentration: 749 nM
Estimate against measurement, compound 4: 1.9-fold (0.27 log units) below, within the range that was stated.
By their numbers in this assay, from the lowest: compound 3; then compounds 2, 4 and 1 (each within the scatter of the next, the first and the last beyond it).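

In this assay, phenyl at this position does not repeat what dimethylamino did: hydroxymethyl and phenyl cannot be told apart (a 1.7-fold lower number from compound 1 to compound 4 (0.24 log units; within the scatter)), while dimethylamino stands clearly apart from phenyl (a 5.9-fold higher number from compound 3 to compound 4 (0.77 log units; beyond the scatter)). The low number of compound 3 therefore does not follow from simply replacing hydroxymethyl with any other group at this place, and a ring of six carbons does not reproduce it. Nothing measured here gives a reason for this difference. Going by these compounds, whether a primary amine, a pyrrolidine or a longer chain carrying dimethylamino would match compound 3 remains open.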